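Ring swap on the ketone carbon of compound 1

This account rests on a few compounds, and the source may have more. Where it says the series, first, only, none or still open, it means among the compounds named here.

Among the compounds with values here, compound 1 `O=C(CCCCCCc1ccccc1)c1ncon1` gives 500 nM in an assay for inhibition of Fatty-acid amide hydrolase 1 (Rattus norvegicus) (on this read-out lower numbers stand for stronger inhibition and higher numbers for weaker inhibition), the highest of the two numbers at hand; compound 2 `O=C(CCCCCCc1ccccc1)c1noc(-c2ccccn2)n1` gives 7 nM, and the step of a 71-fold lower number from compound 1 to compound 2 (1.85 log units; beyond the scatter) is the only measured step. Compound 3 `O=C(CCCCCCc1ccccc1)c1nnn[nH]1` carries 1H-tetrazol-5-yl in place of 1,2,4-oxadiazol-3-yl on a carbonyl carbon. Within the data shown here, no measured step touches that exchange: the step from compound 1 to compound 2 adds pyridin-2-yl to the core and says nothing about replacing the ring itself. The expectation for compound 3 is therefore wide and is estimated as a modest weakening, a 3.0-fold higher number from compound 1 to compound 3 (0.48 log units; beyond the scatter). Compound 3 is estimated at 1500 nM, range 300 nM to 8000 nM.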

Compound 3, half-maximal inhibitory concentration: 600 nM
Compound 3: middle estimate off by 2.5-fold (0.40 log units), on the high side; measured number inside the range.
By their numbers in this assay, from the lowest: compound 2; then compounds 1 and 3 (each within the scatter of the next).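

On a carbonyl carbon, the exchange of 1,2,4-oxadiazol-3-yl for 1H-tetrazol-5-yl gives a 1.2-fold higher number from compound 1 to compound 3 (0.08 log units; within the scatter) in this assay. The earlier step showed only the effect of adding pyridin-2-yl to the ring; this one shows that the ring itself can change, and a hydrogen-bond donor can enter, with no change beyond the scatter. No measurement here accounts for this result.

Open, as far as these compounds go, is whether a carboxylic acid or a thiazole ring on the same carbonyl carbon would read alike. Also open, from the compounds shown here alone, is whether a pyridine group on the 1H-tetrazol-5-yl ring would bring a step like the one seen with pyridin-2-yl on the core of compound 1.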